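A few compounds are considered here, and "the series" means these few. Any claim that something is new, unique, unknown or untested is made for them only; others in the source may bear on it.

The three measured compounds share one core and differ in the group carried on the saturated chain carbon bound to the amide-type nitrogen in the ring. Compound 1 `CS(=O)(=O)Nc1ccc2c(c1)S(=O)(=O)N=C(C1=C(O)[C@H]3CCC[C@H]3N(Cc3ccc(F)c(F)c3)C1=O)N2` is the starting point. In an ADME assay on Huh-7 cells (Homo sapiens) for cytotoxicity, with a stated time of 72 h (a higher number here means that more compound is tolerated, a lower number that less compound is tolerated), compound 1 gives > 1000 nM, which is a limit of the assay and not a number (the limit of > 1000 nM in this assay, at which 1 of the 3 values shown sits). Compound 2 `CS(=O)(=O)Nc1ccc2c(c1)S(=O)(=O)N=C(C1=C(O)C3CCCC3N(Cc3ccc(Cl)cc3)C1=O)N2` in this assay gives > 10000 nM, again only a limit (the limit of > 10000 nM in this assay, at which 1 of the 3 values shown sits). Compound 3 `CS(=O)(=O)Nc1ccc2c(c1)S(=O)(=O)N=C(C1=C(O)[C@@H]3CCCC[C@@H]3N(Cc3ccc(F)cc3)C1=O)N2` in this assay gives > 33000 nM, likewise a limit (the limit of > 33000 nM in this assay, at which 1 of the 3 values shown sits). Compound 1 thus stands at the lowest of the three reported limits, and the numbers shown do not separate the three compounds from one another.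

Compound 4 `CC(C)CCN1C(=O)C(C2=NS(=O)(=O)c3cc(NS(C)(=O)=O)ccc3N2)=C(O)[C@H]2CCC[C@H]21` has not yet been measured. It differs from compound 1 in one place: isobutyl in place of 3,4-difluorophenyl on a saturated chain carbon bound to an amide-type nitrogen in a ring. Among the compounds with values here, no step between measured compounds is available, so the step from compound 1 to compound 4 is expected to be a step that the limit leaves unreadable from compound 1 to compound 4, with no change beyond the scatter in either direction being the likely outcome and a further limit being the most probable report. Compound 4 is expected to give about 20000 nM in this assay, within a range of 3000 nM to 100000 nM.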

Compound 4, half-maximal cytotoxic concentration: > 1000 nM
Compound 4: a limit, no number (the forecaster's own chance of this, stated with the estimate: 80%); the middle value lies beyond the limit too.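

Compound 1 and compound 4 each report only a limit in this assay, and no step can be read between them. The compounds shown leave open at what concentration any of them becomes cytotoxic, and whether exchanging 3,4-difluorophenyl for isobutyl changes that concentration.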